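A few compounds are considered here, and "the series" means these few. Any claim that something is new, unique, unknown or untested is made for them only; others in the source may bear on it.

Series read in a functional assay on NALM-6 cells (Homo sapiens) for cytotoxicity, read by luminescence and CellTiter-Glo, with a stated time of 3 days; a lower number here means a stronger inhibitor, a higher number a weaker inhibitor:
- compound 1 `O=C(Nc1cc(C(F)(F)F)cc(C(F)(F)F)c1)c1ccc(Br)cc1O`: 1200 nM
- compound 2 `O=C(Nc1ccccc1)c1cc(F)ccc1O`: "not determined" (no result reported)
- compound 3 `O=C(Nc1cccc(C(F)(F)F)c1)c1cc(F)ccc1O`: 1800 nM

Among the measured compounds shown here, only two numbers are available so far. Compound 1 and compound 3 lie within the scatter of each other, so the data set no order between them. For the measured compounds named here, compound 2 gives no number to compare, which leaves compound 3, at 1800 nM, with a single close neighbour and no measured step to calibrate against.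

The next compound to be read is compound 4 `O=C(Nc1cc(C(F)(F)F)cc(C(F)(F)F)c1)c1cc(F)ccc1O`. It follows from compound 3 by one change, trifluoromethyl in place of hydrogen on an aromatic carbon. The new group sits meta to a large group and meta to the trifluoromethyl group already present.

Going by the values given here, with no single-point step measured, the size of this change in this assay can only be judged indirectly. Compound 4 has the same trifluoromethyl substitution as compound 1, which gives 1200 nM, and that value offers only weak support for a move toward a lower number. A small step in that direction is expected, probably not beyond the scatter. The expected change is a 1.8-fold lower number from compound 3 to compound 4 (0.26 log units; within the scatter). The estimate for compound 4 is 1000 nM, with an expected range of 350 nM to 2800 nM.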

Compound 4, half-maximal inhibitory concentration: 620 nM
Compound 4: middle estimate off by 1.6-fold (0.21 log units), on the high side, and the stated range covers the measured number.
By their numbers in this assay, from the lowest: compounds 4, 1 and 3 (each within the scatter of the next, the first and the last beyond it).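

Among the compounds shown here, this is the first single-place step that can be read: in this assay, trifluoromethyl in place of hydrogen on an aromatic carbon, meta to a large group and meta to a trifluoromethyl group, gives a 2.9-fold lower number from compound 3 to compound 4 (0.46 log units; beyond the scatter) and so shows that this position responds to the change by more than the scatter. With both trifluoromethyl groups in place, 5-fluoro-2-hydroxyphenyl in place of 4-bromo-2-hydroxyphenyl on a carbonyl carbon gives a 1.9-fold lower number from compound 1 to compound 4 (0.29 log units; within the scatter) and so the values do not separate these two groups. Compound 2 carries no number, which means that the step from it to compound 3 cannot be read and the effect of the first trifluoromethyl group stays unmeasured.

Open, from the compounds shown here alone, is whether a nitrile, an amine or a carboxylic acid at this position would give a step of similar size, and whether a single trifluoromethyl group with 4-bromo-2-hydroxyphenyl on the carbonyl carbon would follow compound 3 or differ from it. The compounds shown come with no measurement that explains the step from compound 3 to compound 4.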